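The source may hold more compounds than are shown below. What is called first, only, known or untested is meant among the compounds shown, and "the series" means these compounds.

In an ADME assay on THP-1 cells (Homo sapiens) for cytotoxicity, read by MTT assay (a higher number here means that more compound is tolerated, a lower number that less compound is tolerated), three compounds have been measured so far. Compound 1 `COc1cc(O)c(C(=O)/C=C/c2cc(OC)c(OC)c(OC)c2)cc1OC` gives a limit of the assay, > 25000 nM. Compound 2 `COc1ccc(O)c(C(=O)/C=C/c2cc(OC)c(OC)c(OC)c2)c1` likewise gives only a limit, > 25000 nM. Compound 3 `COc1cccc(/C=C/C(=O)c2ccccc2O)c1` also gives only a limit, > 25000 nM. From compound 2 to compound 1 the change is methoxy in place of hydrogen on an aromatic carbon, and the step it made is a step that the two limits leave unreadable from compound 2 to compound 1, a consequence of the limit of > 25000 nM in this assay, at which 3 of the 3 values shown sit. The difference between the core of compound 3 and the core of compound 2 is not broken down here.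

Compound 4 `COc1cccc(/C=C/C(=O)c2ccc(OC)cc2O)c1` has not yet been measured. It arises from compound 3 by methoxy in place of hydrogen on an aromatic carbon, the same kind of change, though here the place is not ortho to a methoxy group. In this assay the step from compound 3 to compound 4 is expected to be a step that the limit leaves unreadable from compound 3 to compound 4, because the limit of > 25000 nM in this assay, at which 3 of the 3 values shown sit, leaves the earlier step of this kind unreadable and shows every compound tolerated to the top of the tested range. For compound 4 the estimated value is 40000 nM, expected to lie between 20000 nM and 100000 nM.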

Compound 4, half-maximal cytotoxic concentration: > 25000 nM
Compound 4 gave a limit, no number (the forecaster's own chance of this, stated with the estimate: 80%); the middle value lies beyond the limit too.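

The step from compound 3 to compound 4 cannot be read, because both give only a limit: the limit of > 25000 nM in this assay, at which 4 of the 4 values shown sit. The compounds shown leave open at what concentration any of them becomes cytotoxic in this assay, and whether adding methoxy changes that concentration.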